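Moving a fluorine on a shared scaffold

The source may hold more compounds than are shown below. What is called first, only, known or untested is meant among the compounds shown, and "the series" means these compounds.

Three compounds were examined in a functional assay on NCI-H460 cells (Homo sapiens) for cytotoxicity, read by MTT assay, with a stated time of 72 h; on this read-out higher numbers stand for weaker inhibition and lower numbers for stronger inhibition. Compound 1 `COc1cc2c(Oc3ccc(NC(=O)c4cc(-c5ccc(F)cc5)ccn4)cc3F)ccnc2cc1OCCCN1CCCCC1` gives 250 nM in this assay. Compound 2 `COc1cc2c(Oc3ccc(NC(=O)c4cc(-c5ccccc5F)ccn4)cc3F)ccnc2cc1OCCCN1CCCCC1` gives 130 nM in this assay. Compound 3 `COc1cc2c(Oc3ccc(NC(=O)c4cc(-c5ccc(F)cc5)ccn4)cc3F)ccnc2cc1OCCCN1CCN(C)CC1` gives 430 nM in this assay, the highest of the three numbers, although its gap to compound 1 lies within the scatter and only its gap to compound 2 goes beyond it.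

Two changes connect these compounds. The first is 2-fluorophenyl in place of 4-fluorophenyl on an aromatic carbon, which made the step of a 1.9-fold lower number from compound 1 to compound 2 (0.28 log units; within the scatter). The second is 4-methylpiperazin-1-yl in place of piperidin-1-yl on a saturated chain carbon, three bonds along the chain from an oxygen on an aromatic ring, which made the step of a 1.7-fold higher number from compound 1 to compound 3 (0.24 log units; within the scatter).

Compound 4 `COc1cc2c(Oc3ccc(NC(=O)c4cc(-c5ccccc5F)ccn4)cc3F)ccnc2cc1OCCCN1CCN(C)CC1` has not been measured in this assay. It differs from compound 3 by 2-fluorophenyl in place of 4-fluorophenyl on an aromatic carbon. Among the measured compounds shown here, this is the same change as the one from compound 1 to compound 2, at a place described in the same words; the two cores differ from one another by 4-methylpiperazin-1-yl in place of piperidin-1-yl on a saturated chain carbon, three bonds along the chain from an oxygen on an aromatic ring. The change has been seen once among the compounds here, where it moved the number within the scatter, so the expectation for compound 4 rests on a single earlier step.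

The step expected in this assay is a 1.9-fold lower number from compound 3 to compound 4 (0.27 log units; within the scatter), since the same change gave a 1.9-fold lower number from compound 1 to compound 2 (0.28 log units; within the scatter). For compound 4 the estimated value in this assay is 230 nM, with a likely range from 110 nM to 480 nM.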

Compound 4, half-maximal inhibitory concentration: 140 nM
Estimate against measurement, compound 4: 1.6-fold (0.22 log units) above, within the range that was stated.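

In this assay, 2-fluorophenyl in place of 4-fluorophenyl gave a 3.1-fold lower number from compound 3 to compound 4 (0.49 log units; beyond the scatter), and this step does not differ beyond the scatter from the one seen on the core of compound 1: the same change on two cores in this assay, a 1.9-fold lower number (0.28 log units; within the scatter) from compound 1 to compound 2 and a 3.1-fold lower number (0.49 log units; beyond the scatter) from compound 3 to compound 4, 1.6-fold (0.20 log units) apart, within the scatter of two such steps

The other change, 4-methylpiperazin-1-yl in place of piperidin-1-yl, gave a 1.1-fold higher number from compound 2 to compound 4 (0.03 log units; within the scatter), and it also agrees with its earlier counterpart: the same change on two cores in this assay, a 1.7-fold higher number (0.24 log units; within the scatter) from compound 1 to compound 3 and a 1.1-fold higher number (0.03 log units; within the scatter) from compound 2 to compound 4, 1.6-fold (0.20 log units) apart, within the scatter of two such steps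

Among the compounds shown here, each change therefore carried from one core to the other within the scatter, but this rests on a single pair of cores in one assay, and although only the step from compound 3 to compound 4 lies beyond the scatter, the data do not show that the fluorine move counts for more on the 4-methylpiperazin-1-yl core, nor that either change would carry to any further core.

The compounds shown leave open how an unsubstituted phenyl or a chlorophenyl would compare with the two fluorophenyl groups on these cores. They also leave open whether the agreement would hold with a morpholine at the end of the chain, or with a shorter or longer chain bearing the same amines.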